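A few compounds are considered here, and "the series" means these few. Any claim that something is new, unique, unknown or untested is made for them only; others in the source may bear on it.

Measured compounds and values in a functional assay on HCT-116 cells (Homo sapiens) for antiproliferative activity, read by MTT assay, with a stated time of 72 h; on this read-out lower numbers stand for stronger inhibition and higher numbers for weaker inhibition:

compound 1, `CCC(=O)NNC(=O)c1csc2ncc(-c3ccc(C)cc3)n12`, gives 9230 nM
compound 2, `CCCC(=O)NNC(=O)c1csc2ncc(-c3ccc(C)cc3)n12`, gives 34500 nM
compound 3, `CCC(=O)NNC(=O)c1csc2ncc(-c3ccc(Br)cc3)n12`, gives 25300 nM

Compound 4, `CCCC(=O)NNC(=O)c1csc2ncc(-c3ccc(Br)cc3)n12`, has not yet been measured in this assay.

Compound 1 and compound 3 share a core that differs in one place: bromo in place of methyl on an aromatic carbon. That change gives a 2.7-fold higher number from compound 1 to compound 3 (0.44 log units; beyond the scatter).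

From compound 1 to compound 2 the change is methyl in place of hydrogen on a saturated chain carbon, two bonds along the chain from a carbonyl carbon. The step is a 3.7-fold higher number from compound 1 to compound 2 (0.57 log units; beyond the scatter).

Compound 4 stands to compound 3 exactly as compound 2 stands to compound 1: the change is methyl in place of hydrogen on a saturated chain carbon, two bonds along the chain from a carbonyl carbon, and the place is the same word for word, so this is the same change made on the core of compound 3 instead of the core of compound 1. Among the measured compounds shown here, with only one measured instance of the change, the size of the step it makes on the other core is not fixed; the weakening seen from compound 1 to compound 2 is the only guide, and it is modest but beyond the scatter.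

For compound 4 in this assay the step is expected to be about a 3.2-fold higher number from compound 3 to compound 4 (0.50 log units; beyond the scatter), resting on compound 1 and compound 2 because of a 3.7-fold higher number from compound 1 to compound 2 (0.57 log units; beyond the scatter). Compound 4 is therefore estimated at 80000 nM, with a range from 30000 nM to 200000 nM.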

Compound 4, half-maximal inhibitory concentration: 50300 nM
Estimate against measurement, compound 4: 1.6-fold (0.20 log units) above; the measured number falls inside the stated range.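

In this assay, methyl in place of hydrogen on a saturated chain carbon, two bonds along the chain from a carbonyl carbon, gives a 2.0-fold higher number from compound 3 to compound 4 (0.30 log units; within the scatter), and this step agrees with its earlier counterpart on the other core: the same change on two cores in this assay, a 3.7-fold higher number (0.57 log units; beyond the scatter) from compound 1 to compound 2 and a 2.0-fold higher number (0.30 log units; within the scatter) from compound 3 to compound 4, 1.9-fold (0.27 log units) apart, within the scatter of two such steps. Bromo in place of methyl on an aromatic carbon gives a 1.5-fold higher number from compound 2 to compound 4 (0.16 log units; within the scatter), and this step also agrees with its earlier counterpart: the same change on two cores in this assay, a 2.7-fold higher number (0.44 log units; beyond the scatter) from compound 1 to compound 3 and a 1.5-fold higher number (0.16 log units; within the scatter) from compound 2 to compound 4, 1.9-fold (0.27 log units) apart, within the scatter of two such steps. Both changes therefore carry from one core to the other without a difference that can be told from the scatter, but this rests on a single set of four compounds, and since both new steps are themselves within the scatter, they do not establish a real effect of either change on these cores, nor a step of fixed size across the series.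

Still open, going by these compounds, is whether the same agreement holds for a longer chain, such as butanoyl in place of propylcarbonyl, or for a chain ending in an amine or a carboxylic acid. Also open, on these data alone, is whether chloro or methoxy on the aromatic carbon now holding methyl or bromo would combine with these chain changes in the same way.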